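The source may hold more compounds than are shown below. What is called first, only, known or untested is meant among the compounds shown, and "the series" means these compounds.

Compound 1 `COc1ccc(N)c(C2=NN(C(C)=O)C(C)(C)S2)c1` gives 77.1% in an assay on isolated protein for inhibition of Nitric oxide synthase, inducible (Homo sapiens), read by scintillation counting, with a stated time of 30 min, tested at 50 uM; on this read-out lower numbers stand for less inhibition and higher numbers for more inhibition at the one concentration tested (going by the name of the read-out).
Compound 2 `CCCCC(=O)N1N=C(c2cc(OC)ccc2N)SC1(C)C` gives 101% in this assay.
Compound 3 `COc1ccc(N)c(C2=NN(C(=O)C3CCCC3)C(C)(C)S2)c1` gives 65% in this assay.

Among these three, compound 3 stands lowest. Its nearest neighbour is compound 1, the step being a number 12.1 percentage points lower from compound 1 to compound 3 (beyond the scatter); furthest is compound 2, the step being a number 36 percentage points lower from compound 2 to compound 3 (beyond the scatter). The three compounds share one core and differ only in the group on the carbonyl carbon.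

Compound 4 `COc1ccc(N)c(C2=NN(C(=O)c3ccccc3)C(C)(C)S2)c1` continues that series: phenyl in place of cyclopentyl on a carbonyl carbon. Going by the values given here, the steps that bear on it all change the same carbonyl group: a number 23.9 percentage points higher from compound 1 to compound 2 (beyond the scatter), a number 12.1 percentage points lower from compound 1 to compound 3 (beyond the scatter) and a number 36 percentage points lower from compound 2 to compound 3 (beyond the scatter). Among the compounds with values here, open chains gave higher numbers than a ring, but no measured step swaps one ring for another, so the direction for compound 4 is uncertain. The step of a number 5 percentage points higher from compound 3 to compound 4 (within the scatter) is expected to be small, close to or within the scatter, with the uncertainty allowing either direction. Compound 4 is therefore estimated at 70%, with a range from 45% to 95% in this assay.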

Compound 4, a percentage reported as inhibition, at one concentration (the size of the read-out at that concentration, not a potency): 0%
Compound 4: the middle estimate sits 70 percentage points above what was measured; the measured number lies below the stated range.
By their numbers in this assay, from the lowest: compound 4; then compound 3; then compound 1; then compound 2.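

Replacing cyclopentyl with phenyl gives a number 65 percentage points lower from compound 3 to compound 4 (beyond the scatter) in this assay and shows that a ring on this carbonyl carbon is not interchangeable with another ring of similar size. The phenyl compound also falls well short of both open-chain compounds, with a number 77.1 percentage points lower from compound 1 to compound 4 (beyond the scatter) and a number 101 percentage points lower from compound 2 to compound 4 (beyond the scatter) as the steps, so at this position among these four compounds the benzoyl group stands apart from the methyl, butyl and cyclopentyl versions. No evidence at hand gives a reason for so large a change.

Going by these compounds, it remains open whether cyclohexyl or pyridyl on this carbonyl carbon would behave more like cyclopentyl or like phenyl. On these data alone, it is equally open whether a chlorine or a methoxy group on the phenyl ring would change the result for compound 4.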